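This account rests on a few compounds, and the source may have more. Where it says the series, first, only, none or still open, it means among the compounds named here.

Measured so far:
compound 1 `O=C1/C(=C/c2ccncc2)CN(S(=O)(=O)c2ccc(C(F)(F)F)cc2)C/C1=C\c1ccccc1F` — 11100 nM
compound 2 `O=C1/C(=C/c2ccncc2)CN(S(=O)(=O)c2ccc(F)cc2)C/C1=C\c1ccccc1F` — a limit of the assay, > 20000 nM
compound 3 `O=C1/C(=C/c2cccnc2)CN(S(=O)(=O)c2ccc(C(F)(F)F)cc2)C/C1=C\c1ccccc1C(F)(F)F` — 1730 nM

All three were tested in a functional assay on SMMC-7721 cells (Homo sapiens) for cytotoxicity, read by MTT assay, with a stated time of 24 h; on this read-out higher numbers stand for weaker inhibition and lower numbers for stronger inhibition. Compound 4 `O=C1/C(=C/c2cccnc2)CN(S(=O)(=O)c2ccc(F)cc2)C/C1=C\c1ccccc1C(F)(F)F` has not yet been measured there.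

The change from compound 1 to compound 2 is fluoro in place of trifluoromethyl on an aromatic carbon. That change gave an at least 1.8-fold higher number from compound 1 to compound 2 (0.25 log units; that floor lies within the scatter). Only a floor can be given for this step, since the value of compound 2 is a limit of the assay; it sits at the limit of > 20000 nM in this assay, at which 1 of the 3 values shown sits.

Compound 3 shares the same kind of core but differs from compound 1 in more than one place; the difference between the two cores is not broken down here. Within these two numbers compound 3 gives the lower one, and its gap to compound 1 is beyond the usual scatter.

The same change now goes from compound 3 to compound 4: fluoro in place of trifluoromethyl on an aromatic carbon. The place of the change is described in the same words for both pairs, so it counts as the same change. Because the earlier step, an at least 1.8-fold higher number from compound 1 to compound 2 (0.25 log units; that floor lies within the scatter), is only a floor, the true step may be larger, and the expectation is that compound 4 will give a higher number than compound 3 by a step estimated at a 2.6-fold higher number from compound 3 to compound 4 (0.42 log units; beyond the scatter). Compound 4 is therefore expected to land at about 4500 nM in this assay, estimated to fall between 1700 nM and 14000 nM.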

Compound 4, half-maximal inhibitory concentration: 6390 nM
The estimate for compound 4 lay 1.4-fold (0.15 log units) below the measured number, and the stated range covers the measured number.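

In this assay, putting fluoro in place of trifluoromethyl, which turns a 4-(trifluoromethyl)phenyl into a 4-fluorophenyl, gave a 3.7-fold higher number from compound 3 to compound 4 (0.57 log units; beyond the scatter). This is a clear step on the core of compound 3, but the value of compound 2, > 20000 nM, is a limit of the assay and not a number. The result on the core of compound 3 therefore fits what was seen on the core of compound 1, yet two pairs cannot show that the change has the same size on each core, let alone across the whole series: the same change on two cores in this assay, an at least 1.8-fold higher number (0.25 log units; that floor lies within the scatter) from compound 1 to compound 2 and a 3.7-fold higher number (0.57 log units; beyond the scatter) from compound 3 to compound 4; the limit leaves it open whether they differ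

The compounds shown compare only trifluoromethyl and fluoro at this place on the ring, so it remains open how a methoxy group, a nitrile, an amine or a carboxylic acid would compare there. From the compounds shown here alone, it also remains open whether the change would give a similar step on cores carrying other groups elsewhere, or whether a step could be measured in full on the core of compound 1 in a setting where its fluoro compound gives a number rather than a limit.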